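Working notes: from compound 1 to compound 4

This account rests on a few compounds, and the source may have more. Where it says the series, first, only, none or still open, it means among the compounds named here.

In a functional assay on HepG2 cells (Homo sapiens) for antiproliferative activity, read by MTT assay, with a stated time of 72 h (a lower number here means a stronger inhibitor, a higher number a weaker inhibitor), compound 1 `O=C(N/N=C/c1cccc(Br)c1)Nc1ccc(Oc2ccnc3[nH]ccc23)c(F)c1` gives 660 nM and sits within the scatter of compound 2 `O=C(N/N=C/c1ccc(Br)cc1)Nc1ccc(Oc2ccnc3[nH]ccc23)c(F)c1` at 1000 nM and compound 3 `N#Cc1ccc(/C=N/NC(=O)Nc2ccc(Oc3ccnc4[nH]ccc34)c(F)c2)cc1` at 850 nM in the same read-out. Compound 4 `O=C(N/N=C/c1cccc([N+](=O)[O-])c1)Nc1ccc(Oc2ccnc3[nH]ccc23)c(F)c1` differs from compound 1 by nitro in place of bromo on an aromatic carbon with the rest of the structure unchanged. Among the compounds with values here, no nitro compound has been measured yet. Cyano in place of bromo gave a 1.2-fold lower number from compound 2 to compound 3 (0.07 log units; within the scatter) and the two changes of the aryl group gave a 1.3-fold higher number from compound 1 to compound 3 (0.11 log units; within the scatter) and a 1.5-fold higher number from compound 1 to compound 2 (0.18 log units; within the scatter) as well. No step beyond the scatter is therefore expected in this assay for this change. The estimated step is a 1.2-fold higher number from compound 1 to compound 4 (0.08 log units; within the scatter) and stays within the scatter. For compound 4 the expected value is 800 nM with an estimated range of 350 nM to 1800 nM in this read-out.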

Compound 4, half-maximal inhibitory concentration: 5180 nM
For compound 4 the middle estimate is 6.5-fold (0.81 log units) below the measured one; the whole stated range lies below it.
By their numbers in this assay, from the lowest: compounds 1, 3 and 2 (each within the scatter of the next); then compound 4.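

In this assay, within the data shown here, this aryl position proves not indifferent to its group: nitro in place of bromo gives a 7.8-fold higher number from compound 1 to compound 4 (0.89 log units; beyond the scatter), the first step beyond the scatter. The nitro compound also separates from both 4-substituted compounds, with a 6.1-fold higher number from compound 3 to compound 4 (0.78 log units; beyond the scatter) and a 5.2-fold higher number from compound 2 to compound 4 (0.71 log units; beyond the scatter), whereas compounds 1, 2 and 3 stand within the scatter of one another. Nothing available explains this weaker result.

From the compounds shown here alone, whether the step is peculiar to nitro or would also appear with an amine or a carboxylic acid on this carbon stays open.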